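Removing the aryl arm of a fatty-acid amide hydrolase inhibitor

This account rests on a few compounds, and the source may have more. Where it says the series, first, only, none or still open, it means among the compounds named here.

Measured compounds:
compound 1, `O=C(CCCCCCc1ccccc1)c1ncc(-c2ccccc2F)o1`, 110 nM
compound 2, `NC(=O)c1cccc(-c2cnc(C(=O)CCCCCCc3ccccc3)o2)n1`, 1 nM

Among the measured compounds shown here, in an assay (Rattus norvegicus) for inhibition of Fatty-acid amide hydrolase 1 (Homo sapiens) (a lower number here means a stronger inhibitor, a higher number a weaker inhibitor), compound 2 gives the lowest number of the two; compound 1, its only comparison, lies far higher, and the single known step, a 110-fold lower number from compound 1 to compound 2 (2.04 log units; beyond the scatter), shows how much the ring attached to the shared core matters. Compound 3, `CSc1cnc(C(=O)CCCCCCc2ccccc2)o1`, has not yet been measured. Its difference from compound 2 is methylsulfanyl in place of 6-carbamoylpyridin-2-yl on an aromatic carbon. For the measured compounds named here, no step in the data puts a group this small at that position, so the only guide is the large gain seen when the 2-fluorophenyl became 6-carbamoylpyridin-2-yl; taking that ring away entirely is expected to cost more than the whole of that gain. Compound 3 is therefore expected to give 250 nM, within 40 nM to 1500 nM, a step of a 250-fold higher number from compound 2 to compound 3 (2.40 log units; beyond the scatter) toward weaker inhibition.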

Compound 3, inhibition constant: 25 nM
Estimate against measurement, compound 3: 10-fold (1.00 log units) above; measured number outside the range, below it.
By their numbers in this assay, from the lowest: compound 2; then compound 3; then compound 1.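

In this assay, an aromatic ring at this position turns out not to be required for a fairly low number: methylsulfanyl, which has no ring, gives a 4.4-fold lower number from compound 1 to compound 3 (0.64 log units; beyond the scatter) when it replaces 2-fluorophenyl. The ring cannot simply be dropped without cost, however, as replacing 6-carbamoylpyridin-2-yl with methylsulfanyl gives a 25-fold higher number from compound 2 to compound 3 (1.40 log units; beyond the scatter), so the nature of the group decides the outcome here, not just the presence or size of a ring. Nothing at hand accounts for why the three groups fall in this order.

Still open, on these data alone, is how much of the low number of compound 2 comes from its carbamoyl group and how much from its pyridine ring, a question that an unsubstituted pyridin-2-yl or a 3-carbamoylphenyl group would address. It is also unknown whether the sulfur matters, which a methoxy or an ethyl group at this position would test.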